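Chloro to hydroxy exchange on the amide arm of compound 2

A few compounds are considered here, and "the series" means these few. Any claim that something is new, unique, unknown or untested is made for them only; others in the source may bear on it.

Measured so far in a functional assay on A549 cells (Homo sapiens) for antiproliferative activity, read by MTT assay, with a stated time of 72 h; a lower number here means a stronger inhibitor, a higher number a weaker inhibitor:
compound 1 `COc1cc(F)c(NC(=O)c2ccnc(O)c2)cc1Nc1nccc(-c2cn(C)c3ccccc23)n1` gives 11700 nM
compound 2 `COc1cc(N(C)CCN(C)C)c(NC(=O)c2ccnc(Cl)c2)cc1Nc1nccc(-c2cn(C)c3ccccc23)n1` gives 970 nM

Compound 2 stands as the lower of the two numbers in this assay; compound 1 sits higher by a margin beyond the scatter. Going by the values given here, the two compounds differ in two places at once, so the two values show only that compound 2 is the stronger inhibitor here, and no single change can be read from that gap.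

Compound 3 `COc1cc(N(C)CCN(C)C)c(NC(=O)c2ccnc(O)c2)cc1Nc1nccc(-c2cn(C)c3ccccc23)n1` is not yet measured. It keeps the amine side chain of compound 2 and changes only the amide arm: hydroxy in place of chloro on an aromatic carbon. Among the compounds with values here, no measured pair isolates this exchange. Within the data shown here, compound 1, the only compound that carries the hydroxy group, gives 11700 nM, but its other difference from compound 2 leaves that value unassigned. The step is expected to go toward a weaker inhibitor, moderate in size and beyond the scatter, as a 2.6-fold higher number from compound 2 to compound 3 (0.41 log units; beyond the scatter). Compound 3 is estimated at 2500 nM, with a range from 900 nM to 8000 nM.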

Compound 3, half-maximal inhibitory concentration: 11200 nM
Compound 3: the middle estimate sits 4.5-fold (0.65 log units) below what was measured, and the stated range ends below it.
By their numbers in this assay, from the lowest: compound 2; then compounds 3 and 1 (each within the scatter of the next).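

With the amine side chain held fixed, the exchange of 2-chloropyridin-4-yl for 2-hydroxypyridin-4-yl on the amide arm can now be read on its own: in this assay it gives a 12-fold higher number from compound 2 to compound 3 (1.06 log units; beyond the scatter) and so counts as a large step toward a weaker inhibitor at this aromatic carbon next to the ring nitrogen. With hydroxy in place on the arm, the other exchange, (2-(dimethylamino)ethyl)(methyl)amino in place of fluoro on an aromatic carbon, gives a 1.0-fold lower number from compound 1 to compound 3 (0.02 log units; within the scatter) and so leaves the number unmoved, which means that the high value of compound 1 need no longer stay unassigned between its two differences from compound 2, at least as far as these steps go. No measurement at hand gives a reason for the size of the chloro to hydroxy step.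

Going by these compounds alone, whether the side chain exchange would also stay within the scatter on the chloro arm remains open, since the single reading of it rests on the hydroxy arm. Also open, going by these compounds, is whether the step reflects the departure of chloro or the arrival of hydroxy, a question that an amino group, a methoxy group or a plain hydrogen on the same aromatic carbon would help to separate.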